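The source may hold more compounds than are shown below. What is called first, only, known or untested is meant among the compounds shown, and "the series" means these compounds.

Of the compounds shown here, three have so far been tested in an ADME assay on Ava5 cells (Homo sapiens) for cytotoxicity; on this read-out higher numbers stand for lower toxicity in this test and lower numbers for higher toxicity in this test. Compound 1 `NC(=S)Nc1cccc(OCCCCCCc2ccccc2)c1` gives 28000 nM. Compound 2 `NC(=S)Nc1ccccc1OCCCCCc1ccccc1` gives 31000 nM, and the two numbers lie within the usual scatter of each other. Compound 3 `CNC(=S)Nc1cccc(OCCCCCc2ccccc2)c1` gives > 50000 nM, which is a limit of this assay rather than a number (the limit of > 50000 nM in this assay, at which 1 of the 3 values shown sits). Compound 1 thus stands with the lower of the two plain numbers, though the gap to compound 2 lies within the scatter, so the two cannot be ranked. Compound 4 `NC(=S)Nc1cccc(OCCCCCOc2ccc(Cl)cc2)c1` differs from compound 1 by a single change: 4-chlorophenoxy in place of benzyl on a saturated chain carbon, five bonds along the chain from an oxygen on an aromatic ring. For the measured compounds named here, no measured pair shows what such a change does here, so the expected step is small, within the scatter and in no set direction, a 1.1-fold higher number from compound 1 to compound 4 (0.03 log units; within the scatter). On that basis compound 4 is estimated at 30000 nM, with a range from 12000 nM to 70000 nM.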

Compound 4, half-maximal cytotoxic concentration: 7000 nM
The estimate for compound 4 lay 4.3-fold (0.63 log units) above the measured number; the measured number lies below the stated range.
By their numbers in this assay, from the lowest: compound 4; then compounds 1 and 2 (each within the scatter of the next). At a limit, above all of these: compound 3.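

In this assay, 4-chlorophenoxy in place of benzyl, on a saturated chain carbon five bonds along the chain from an oxygen on an aromatic ring, brings a 4.0-fold lower number from compound 1 to compound 4 (0.60 log units; beyond the scatter), which here means higher toxicity in this test. So the group at this position can move the read-out beyond the scatter. Nothing measured here explains the step.

The compounds shown leave open whether the chlorine or the added oxygen carries this step. A plain phenoxy group, without chlorine, would separate the two.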